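The source may report more compounds than this note shows. Statements on the series, on what has been measured and on what is new or still open speak of the compounds shown alone.

In a toxicity assay on the whole organism (strain Icem-CET (SPF Caw)) for cytotoxicity, with Mus musculus as the target (on this read-out higher numbers stand for an effect only at larger amounts of compound and lower numbers for an effect already at smaller amounts), three compounds sharing one core have been measured. Compound 1 `C=CCNC(=O)/C(C)=C(/C)c1ccc(OC)cc1` gives 280 mg/kg. Compound 2 `COc1ccc(/C(C)=C(/C)C(=O)NC2CC2)cc1` gives 300 mg/kg, the highest of the three numbers, yet its distance to each of the other two lies within the scatter, so no ranking can be drawn from it. Compound 3 `COc1ccc(/C(C)=C(\C)C(=O)NC2CC2)cc1` gives 250 mg/kg.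

Both measured steps are small. Exchanging allyl for cyclopropyl on the amide-type nitrogen gave a 1.1-fold higher number from compound 1 to compound 2 (0.03 log units; within the scatter). The second step rests on the fact that compounds 2 and 3 differ only in the configuration as drawn and gave a 1.2-fold lower number from compound 2 to compound 3 (0.08 log units; within the scatter). Neither of them altered the aromatic ring, so neither speaks directly to the change now in view.

Compound 4 `C/C(C(=O)NC1CC1)=C(\C)c1ccc(Br)cc1` differs from compound 2 in one place: bromo in place of methoxy on an aromatic carbon. For the measured compounds named here, because the only measured steps, a 1.1-fold higher number from compound 1 to compound 2 (0.03 log units; within the scatter) and a 1.2-fold lower number from compound 2 to compound 3 (0.08 log units; within the scatter), stayed within the scatter, the core appears tolerant of small edits at the amide end, but the aromatic position has not been varied among the measured compounds, so the expectation for compound 4 carries real uncertainty. The step from compound 2 to compound 4 is expected to be a 1.2-fold lower number from compound 2 to compound 4 (0.08 log units; within the scatter), not beyond the scatter. For compound 4 the expected value in this assay is 250 mg/kg, estimated to fall between 120 mg/kg and 500 mg/kg.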

Compound 4, dose for half-maximal effect: 300 mg/kg
For compound 4 the middle estimate is 1.2-fold (0.08 log units) below the measured one, within the range that was stated.
By their numbers in this assay, from the lowest: compounds 3, 1, 2 and 4 (each within the scatter of the next).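

For the compounds shown here, this is the first look at the aromatic ring of the shared core: bromo in place of methoxy on an aromatic carbon, para to a large group, gave no change at the digits printed from compound 2 to compound 4 (within the scatter) in this assay. By the computed counts, methoxy has two heavy atoms, including an oxygen that serves as a hydrogen-bond acceptor, whereas bromo is a single heavy atom with no hydrogen-bond acceptor, so for this pair the exchange of quite different groups leaves no readable difference in the dose. Nothing available bears on why these two groups read alike in this whole-animal test.

This single pair cannot show whether an amine, a carboxylic acid or a longer chain such as butoxy on the same aromatic carbon would also stay within the scatter of compound 2. It also leaves open whether bromo in place of methoxy would read the same way with the allyl group of compound 1 on the amide nitrogen, or with the double-bond configuration drawn in compound 3.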